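The compounds below may be only part of what the source reports. "The series", "measured", "known", "first", "only" and "open" are said of these compounds alone.

Compound 3 `Cc1nn(-c2ncnc3nc[nH]c23)c2c1C(OCc1ccc(F)cc1)CC(=O)N2` gives the lowest number among the three measured compounds in a functional assay on HEK293 cells for agonist activity at G-protein coupled receptor 39 (Homo sapiens), read by scintillation proximity assay and inositol phosphate accumulation, with a stated time of 75 min, in the presence of a further agent that is not named here (a lower number here means that less compound is needed, a higher number that more compound is needed for the effect), at 1 nM. Compound 1 `Cc1noc(C)c1COC1CC(=O)Nc2c1c(C)nn2-c1ncnc2nc[nH]c12` gives 5 nM and compound 2 `Cc1nn(-c2ncnc3nc[nH]c23)c2c1C(OCCn1nccc1C)CC(=O)N2` gives 10 nM in this assay. Compound 4 `Cc1nn(-c2ncnc3nc[nH]c23)c2c1C(OCCn1cccn1)CC(=O)N2` differs from compound 3 by one change: (1H-pyrazol-1-yl)methyl in place of 4-fluorophenyl on a saturated chain carbon bound to an oxygen on a saturated carbon. The closest measured comparison runs the other way, a 10-fold lower number from compound 2 to compound 3 (1.00 log units; beyond the scatter), and a related one is a 5.0-fold lower number from compound 1 to compound 3 (0.70 log units; beyond the scatter); the pair a 2.0-fold higher number from compound 1 to compound 2 (0.30 log units; within the scatter) shows that the methyl on the pyrazole matters little. Undoing that kind of change is therefore expected to raise the number again, a 10-fold higher number from compound 3 to compound 4 (1.00 log units; beyond the scatter). Compound 4 is expected to give about 10 nM in this assay, most likely between 3 nM and 30 nM.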

Compound 4, half-maximal effective concentration: 16 nM
Beside the measured number, compound 4's estimate is 1.6-fold (0.20 log units) below it, and the stated range covers the measured number.
By their numbers in this assay, from the lowest: compound 3; then compounds 1, 2 and 4 (each within the scatter of the next, the first and the last beyond it).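

In this assay, replacing the 4-fluorobenzyl group with 2-(1H-pyrazol-1-yl)ethyl is a large loss, a 16-fold higher number from compound 3 to compound 4 (1.20 log units; beyond the scatter). The methyl on the pyrazole is not what separates these compounds from compound 3, since removing it gives a 1.6-fold higher number from compound 2 to compound 4 (0.20 log units; within the scatter), which is within the scatter. The unsubstituted pyrazole does separate from the 3,5-dimethyl-1,2-oxazol-4-yl group, a 3.2-fold higher number from compound 1 to compound 4 (0.51 log units; beyond the scatter), a gap that did not exceed the scatter with the methylated pyrazole.

Nothing shown here explains these steps. On these data alone, whether an amine or a carboxylic acid in place of the pyrazole would bring the number closer to that of compound 3 remains open.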